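Side-chain extension on the sulfur-linked chain of compound 3

A few compounds are considered here, and "the series" means these few. Any claim that something is new, unique, unknown or untested is made for them only; others in the source may bear on it.

Measured so far in an assay for inhibition of Indoleamine 2,3-dioxygenase 1 (Homo sapiens), read by fluorescence, with a stated time of 1 h; on this read-out lower numbers stand for stronger inhibition and higher numbers for weaker inhibition:
compound 1 `NS(=O)(=O)NCCSc1nonc1/C(=N/O)Nc1ccc(F)c(Br)c1` gives 130 nM
compound 2 `N#Cc1cccc(N/C(=N\O)c2nonc2SCCNC(=O)CS(N)(=O)=O)c1` gives 240 nM
compound 3 `CSc1nonc1/C(=N/O)Nc1ccc(F)c(Br)c1` gives 560 nM

Compound 3 stands highest of the three numbers in this assay; compound 2 sits nearer to it and compound 1 furthest below it, both gaps beyond the scatter. Among the compounds with values here, the single step between measured compounds that differ in one place is a 4.3-fold higher number from compound 1 to compound 3 (0.63 log units; beyond the scatter), so cutting the chain back to a bare hydrogen at that carbon weakened inhibition to a modest degree.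

Compound 4 `NS(=O)(=O)CC(=O)NCCSc1nonc1/C(=N/O)Nc1ccc(F)c(Br)c1` goes the other way: a group of 9 heavy atoms (3 carbon, 2 nitrogen, 3 oxygen, 1 sulfur; no ring) in place of a hydrogen atom, on a saturated chain carbon bound to a sulfur. Within the data shown here, the entering group is not the one carried by compound 1, so that step serves only as a guide to size. Among the measured compounds shown here, compound 2 bears the same entering group on a different aryl ring, and its number lies between those of compound 1 and compound 3; no single-point step links it to compound 4, so it shows only that this chain is compatible with strong inhibition. The step in this assay from compound 3 to compound 4 is therefore expected to be downward, roughly mirroring a 4.3-fold higher number from compound 1 to compound 3 (0.63 log units; beyond the scatter). Compound 4 is expected at 160 nM with a range of 60 nM to 420 nM, an expected step of a 3.5-fold lower number from compound 3 to compound 4 (0.54 log units; beyond the scatter).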

Compound 4, half-maximal inhibitory concentration: 71 nM
Compound 4: middle estimate off by 2.3-fold (0.35 log units), on the high side; measured number inside the range.
By their numbers in this assay, from the lowest: compounds 4, 1 and 2 (each within the scatter of the next, the first and the last beyond it); then compound 3.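

In this assay, the group of 9 heavy atoms on the saturated chain carbon bound to a sulfur improves on the bare hydrogen (a 7.9-fold lower number from compound 3 to compound 4 (0.90 log units; beyond the scatter)), so this position accepts the full chain with the 3-bromo-4-fluorophenyl group in place. Replacing sulfamoyl with (sulfamoylmethyl)carbonyl on the amine nitrogen leaves the number within the scatter (a 1.8-fold lower number from compound 1 to compound 4 (0.26 log units; within the scatter)), so these two chain ends cannot be told apart on this read-out, and the gain over the bare hydrogen does not depend on one exact chain end. With the chain held constant, 3-bromo-4-fluorophenyl in place of 3-cyanophenyl on an amine nitrogen gives a step beyond the scatter (a 3.4-fold lower number from compound 2 to compound 4 (0.53 log units; beyond the scatter)), which shows that the aryl group still matters when this longer chain is present.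

No available evidence bears on the reason for these steps. On these data alone, it remains open whether a carboxylic acid, a simple primary amine or a longer chain in place of the terminal sulfamoyl group would hold the number seen for compound 4.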